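This account rests on a few compounds, and the source may have more. Where it says the series, first, only, none or still open, it means among the compounds named here.

Compound 1 `c1ccc(Cn2c(Nc3ccccc3)nc3cccnc32)cc1` in a functional assay on HCT-116 cells (Homo sapiens) for antiproliferative activity, read by MTT assay, with a stated time of 72 h (on this read-out lower numbers stand for stronger inhibition of growth and higher numbers for weaker inhibition of growth), gives 60200 nM. Compound 2 `Cn1nc(-c2ccnc(Nc3cccc(S(N)(=O)=O)c3)n2)c2ccccc21` gives 1980 nM in this assay, and compound 3 `CCn1nc(-c2ccnc(Nc3cccc(S(N)(=O)=O)c3)n2)c2ccccc21` gives 9010 nM. Among the three numbers compound 3 stands second highest: its nearest neighbour is compound 2, whose number is lower, and the one furthest from it is compound 1, whose number is higher. Among the measured compounds shown here, the only single-point step measured so far, a 4.6-fold higher number from compound 2 to compound 3 (0.66 log units; beyond the scatter), concerns the saturated chain on the aromatic nitrogen and not the substituent on the aromatic ring.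

Compound 4 `CCn1nc(-c2ccnc(Nc3cccc(O)c3)n2)c2ccccc21` differs from compound 3 by hydroxy in place of sulfamoyl on an aromatic carbon. For the measured compounds named here, no measured pair changes anything at this aromatic carbon, so the step from compound 2 to compound 3 has no direct bearing, and the series holds no precedent for exchanging the group that sits meta to a large group. Any expectation therefore rests only on the position of compound 3 within this assay and on the fact that one substituent is exchanged for another at this place. The expected step is a 1.8-fold higher number from compound 3 to compound 4 (0.25 log units; within the scatter), a modest rise in the number carrying wide uncertainty. Compound 4 is estimated at 16000 nM, with a range from 4000 nM to 64000 nM.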

Compound 4, concentration for 50% growth inhibition: 36600 nM
Compound 4: the middle estimate sits 2.3-fold (0.36 log units) below what was measured; the range from low to high includes it.
By their numbers in this assay, from the lowest: compound 2; then compound 3; then compounds 4 and 1 (each within the scatter of the next).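

This aromatic carbon, meta to a large group, is not indifferent to its substituent: in this assay, hydroxy in place of sulfamoyl gives a 4.1-fold higher number from compound 3 to compound 4 (0.61 log units; beyond the scatter), a change beyond the scatter and the first measured at this place. Among the compounds shown here, until now the only single-point step concerned the saturated chain on the aromatic nitrogen, so the series now has a modest step at each of two separate places, and here the sulfamoyl compound has the lower number. The count of hydrogen-bond donors is the same on both sides of the exchange, yet the number still rises, and nothing measured here accounts for the rise.

On these data alone, it remains open whether this step carries over to the chain on the aromatic nitrogen of compound 2, since a single pair cannot show whether the two changes act independently. Also open, as far as these compounds go, is where an amine, a carboxylic acid or a methanesulfonyl group at this aromatic carbon would fall relative to sulfamoyl and hydroxy, and whether a plain hydrogen there would give a number nearer compound 3 or compound 4.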